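Swapping the amide substituent of compound 1 for propyl

This account rests on a few compounds, and the source may have more. Where it says the series, first, only, none or still open, it means among the compounds named here.

Measured so far in an ADME assay on HEK293 cells (Homo sapiens) for antiproliferative activity, read by MTT assay; a lower number here means a stronger inhibitor, a higher number a weaker inhibitor:
- compound 1 `Nc1c(C(=O)N/N=C/c2ccc(Br)cc2)oc2nc(-c3cccs3)cc(C(F)(F)F)c12` gives 86000 nM
- compound 2 `Nc1c(C(=O)N/N=C/c2ccccc2)oc2nc(-c3cccs3)cc(C(F)(F)F)c12` gives 72000 nM
- compound 3 `CCCNC(=O)c1oc2nc(-c3ccccc3)cc(C(F)(F)F)c2c1N` gives 81000 nM

Compound 1 stands within the scatter of both other compounds, so the three values set no order among them. Compound 4 `CCCNC(=O)c1oc2nc(-c3cccs3)cc(C(F)(F)F)c2c1N` has not yet been measured. Its change from compound 1 is a group of 3 heavy atoms (3 carbon; no ring) in place of a group of 9 heavy atoms (7 carbon, 1 nitrogen, 1 bromine; one six-membered aromatic ring of carbon only), on an amide-type nitrogen, so propyl takes the place of the larger group on the amide-type nitrogen.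

Among the measured compounds shown here, only one measured step touches the departing group: hydrogen in place of bromo gave a 1.2-fold lower number from compound 1 to compound 2 (0.08 log units; within the scatter), a change within the scatter. That step does not test removal of the whole group. Compound 3 also carries propyl on an amide-type nitrogen and gives 81000 nM, although its core is not the core of compound 1. Its value lies within the scatter of the value of compound 1.

No step beyond the scatter is therefore expected in this assay, and the estimated step is (a 1.1-fold lower number from compound 1 to compound 4 (0.03 log units; within the scatter)). For compound 4 the expected value is 80000 nM, with an estimated range of 45000 nM to 140000 nM.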

Compound 4, half-maximal inhibitory concentration: 64000 nM
Compound 4: middle estimate off by 1.3-fold (0.10 log units), on the high side, within the range that was stated.
By their numbers in this assay, from the lowest: compounds 4, 2, 3 and 1 (each within the scatter of the next).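

In this assay, among the compounds shown here, exchanging the whole larger group on the amide-type nitrogen for propyl stays within the scatter, both with the bromo group present, a 1.3-fold lower number from compound 1 to compound 4 (0.13 log units; within the scatter), and without it, a 1.1-fold lower number from compound 2 to compound 4 (0.05 log units; within the scatter), whereas the earlier bromo step had tested only a single atom of that group. For the compounds shown here, compound 4 also gives the first direct comparison at the aromatic carbon, where thiophen-2-yl in place of phenyl, a 1.3-fold lower number from compound 3 to compound 4 (0.10 log units; within the scatter), likewise stays within the scatter. No measurement shown here offers an explanation for this result.

None of the changes shown produces a step beyond the scatter, so it remains open whether either position can move the number in this assay at all. A longer chain or a carboxylic acid on the amide-type nitrogen, or an amine on the aromatic carbon, would test this further.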